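Aryl amine series: from compound 2 to compound 3

The compounds below may be only part of what the source reports. "The series", "measured", "known", "first", "only" and "open" are said of these compounds alone.

- compound 1 `O=C1C(Nc2ccc(I)cc2)=CC(=O)c2c1nc1n2[C@H]2OC[C@@H](O)[C@H]2OC1`: 2530 nM
- compound 2 `CCOc1ccc(NC2=CC(=O)c3c(nc4n3[C@H]3OC[C@@H](O)[C@H]3OC4)C2=O)cc1`: > 4000 nM (a limit)

In a functional assay on ECa-109 cells for inhibition, with ECa-109 cell line (Homo sapiens) as the target, read by sulforhodamine B assay (a higher number here means a weaker inhibitor, a lower number a stronger inhibitor), compound 2 gives > 4000 nM, which is a limit and not a number. Compound 2 therefore stands at the limit of > 4000 nM in this assay, at which 1 of the 2 values shown sits.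

Compound 3 `O=C1C(Nc2cccc(Cl)c2)=CC(=O)c2c1nc1n2[C@H]2OC[C@@H](O)[C@H]2OC1` carries 3-chlorophenyl in place of 4-ethoxyphenyl on an amine nitrogen.

Among the measured compounds shown here, the one measured step bearing on this change is an at least 1.5-fold higher number from compound 1 to compound 2 (0.19 log units; that floor lies within the scatter), with ethoxy in place of iodo on an aromatic carbon. It sets no firm size. Like compound 3, compound 1 carries a halogen on its phenyl ring and gives 2530 nM. A modest move to a lower number in this assay is therefore expected, possibly no larger than the scatter. The estimated change is an at least 1.6-fold lower number from compound 2 to compound 3 (0.20 log units; that floor lies within the scatter). For compound 3 the expected value is 2500 nM, with an estimated range from 1000 nM to 6000 nM.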

Compound 3, half-maximal inhibitory concentration: 3080 nM
The estimate for compound 3 lay 1.2-fold (0.09 log units) below the measured number; measured number inside the range.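

In this assay, swapping 4-iodophenyl for 3-chlorophenyl on the amine nitrogen leaves no separable difference: a 1.2-fold higher number from compound 1 to compound 3 (0.09 log units; within the scatter). At this position, the change of halogen and of its printed name on the ring therefore does not shift the reading beyond the scatter. Against the 4-ethoxyphenyl group, the comparison gives only a floor and does not establish a real gain: an at least 1.2-fold lower number from compound 2 to compound 3 (0.11 log units; that floor lies within the scatter). Compound 2 remains a limit and not a number: the limit of > 4000 nM in this assay, at which 1 of the 3 values shown sits.

From the compounds shown here alone, whether a phenyl ring bearing a carboxylic acid or a dimethylamino group would move the number beyond the scatter remains open. The same holds for a benzyl group on the amine nitrogen, and the true size of the gap between the 4-ethoxyphenyl and 3-chlorophenyl groups is also unresolved.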